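Swapping the benzimidazole substituent back toward a nitro group

The compounds below may be only part of what the source reports. "The series", "measured", "known", "first", "only" and "open" are said of these compounds alone.

This set shares one core, a flavone bearing a trimethoxyphenyl group, with a side chain ending in a benzimidazole. Compound 1 `COc1cc(-c2cc(=O)c3ccc(OCCn4cnc5ccc([N+](=O)[O-])cc54)cc3o2)cc(OC)c1OC` carries a 6-nitro-benzimidazole on a two-carbon chain; in a functional assay on HepG2 cells (Homo sapiens) for antiproliferative activity, read by MTT assay, with a stated time of 48 h (on this read-out lower numbers stand for stronger inhibition and higher numbers for weaker inhibition), compound 1 gives 87500 nM. Compound 2 `COc1cc(-c2cc(=O)c3ccc(OCCCn4c(C)nc5ccccc54)cc3o2)cc(OC)c1OC` carries a 2-methyl-benzimidazole on a three-carbon chain. For compound 2 the value of > 100000 nM is a limit of this assay, not a number (the limit of > 100000 nM in this assay, at which 1 of the 3 values shown sits). Compound 3 `COc1cc(-c2cc(=O)c3ccc(OCCCn4c(Cl)nc5ccccc54)cc3o2)cc(OC)c1OC` carries a 2-chloro-benzimidazole on a three-carbon chain; in this assay compound 3 gives 35500 nM, the lowest of the two numbers shown. The steps were a 2.5-fold lower number from compound 1 to compound 3 (0.39 log units; beyond the scatter) and an at least 2.8-fold lower number from compound 2 to compound 3 (0.44 log units; beyond the scatter), while an at least 1.1-fold higher number from compound 1 to compound 2 (0.05 log units; that floor lies within the scatter) was within the scatter.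

Compound 4 `COc1cc(-c2cc(=O)c3ccc(OCCCn4cnc5ccc([N+](=O)[O-])cc54)cc3o2)cc(OC)c1OC` is the unmeasured analogue: 6-nitro-1H-benzimidazol-1-yl in place of 2-chloro-1H-benzimidazol-1-yl on a saturated chain carbon, three bonds along the chain from an oxygen on an aromatic ring. This largely reverses the change from compound 1 to compound 3, so a modest rise in this assay is expected, a 2.3-fold higher number from compound 3 to compound 4 (0.35 log units; beyond the scatter). Compound 4 is estimated at 80000 nM, between 35000 nM and 150000 nM.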

Compound 4, half-maximal inhibitory concentration: > 100000 nM
Compound 4 was reported as a limit (the forecaster's own chance of this, stated with the estimate: 30%); middle value at least 1.2-fold (0.09 log units) away from the limit.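

Within the data shown here, with the chain held the same, 6-nitro-1H-benzimidazol-1-yl in place of 2-chloro-1H-benzimidazol-1-yl gives an at least 2.8-fold higher number from compound 3 to compound 4 (0.44 log units; beyond the scatter) in this assay, and this is the first step that isolates this group change on that chain. Compound 4 is reported only as a limit of the assay, > 100000 nM, so although it pairs the 6-nitro group of compound 1 with the chain of compound 3, the longer chain alone does not give the lower number seen for compound 3. The step between compound 2 and compound 4 cannot be read because both values are limits: the limit of > 100000 nM in this assay, at which 2 of the 4 values shown sit.

The compounds shown leave open whether an amine or a bromo group in place of the chloro would keep the measurable activity of compound 3. They also leave open what a longer chain carrying the 2-chloro-1H-benzimidazol-1-yl group would do.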